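From trifluorophenyl to bromochlorophenyl: an outlook for compound 4

This account rests on a few compounds, and the source may have more. Where it says the series, first, only, none or still open, it means among the compounds named here.

Compound 1, `N#Cc1ccc(NCCNc2ncc(-c3ncc[nH]3)c(-c3ccc(Cl)cc3Cl)n2)nc1`, gives in an ADME assay on microsomes from liver (Rattus norvegicus) for metabolic stability; on this read-out lower numbers stand for a shorter-lived compound and higher numbers for a longer-lived compound > 0.5 h, which is a limit of the assay rather than a number.
Compound 2, `Clc1ccc(-c2nc(NCCNc3ccccn3)ncc2-c2ncc[nH]2)c(Cl)c1`, gives in this assay > 0.5 h, likewise a limit.
Compound 3, `Nc1nc(NCCNc2ncc(-c3ncc[nH]3)c(-c3cc(F)c(F)cc3F)n2)ccc1[N+](=O)[O-]`, gives in this assay > 0.5 h, again a limit.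

All three measured compounds thus sit at the same edge of the assay, (the limit of > 0.5 h in this assay, at which 3 of the 3 values shown sit), and compound 3 stands there too, with no number above the limit. Among the measured compounds shown here, the only comparison between measured compounds, hydrogen in place of cyano on an aromatic carbon, is a step that the two limits leave unreadable from compound 1 to compound 2, so it offers no size to work with. Compound 4, `Nc1nc(NCCNc2ncc(-c3ncc[nH]3)c(-c3ccc(Cl)cc3Br)n2)ccc1[N+](=O)[O-]`, differs from compound 3 by 2-bromo-4-chlorophenyl in place of 2,4,5-trifluorophenyl on an aromatic carbon. For the measured compounds named here, no measured step bears on this change; the values of compounds 1, 2 and 3 show only that each reached the limit. The expected step is therefore a step that the limit leaves unreadable from compound 3 to compound 4, none beyond the scatter, in no particular direction. Compound 4 is estimated at 1.5 h, with a range from 0.4 h to 6 h.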

Compound 4, half-life: > 0.5 h
Compound 4: no number, only a limit (the forecaster's own chance of this, stated with the estimate: 70%); the middle value lies beyond the limit too.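

Compound 3 and compound 4 each give a limit in this assay rather than a number, so no step can be read between them: the limit of > 0.5 h in this assay, at which 4 of the 4 values shown sit.

From the compounds shown here alone, what half-life compound 3 and compound 4 actually have, and whether 2-bromo-4-chlorophenyl in place of 2,4,5-trifluorophenyl changes it at all, stays open.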